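The compounds below may be only part of what the source reports. "The series", "measured", "known", "first", "only" and "open" are said of these compounds alone.

Measured in a functional assay on SK-OV-3 cells (Homo sapiens) for antiproliferative activity, read by MTT assay, with a stated time of 72 h; on this read-out higher numbers stand for weaker inhibition and lower numbers for stronger inhibition:
- compound 1 `O=C(CCc1cccc2c1B(O)OC2)Nc1cccc(-c2cccc(Cl)c2)c1`: 300 nM
- compound 2 `O=C(CCc1cccc2c1B(O)OC2)Nc1cccc(-c2cccc(C(F)(F)F)c2)c1`: 390 nM
- compound 3 `O=C(CCc1cccc2c1B(O)OC2)Nc1cccc(-c2ccc(C(F)(F)F)cc2)c1`: 500 nM

The three values sit close together, and compound 3, at 500 nM, cannot be separated from the other two. The measured steps are a 1.7-fold higher number from compound 1 to compound 3 (0.22 log units; within the scatter) and a 1.3-fold higher number from compound 2 to compound 3 (0.11 log units; within the scatter).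

Compound 4 `N#Cc1ccc(-c2cccc(NC(=O)CCc3cccc4c3B(O)OC4)c2)cc1` has cyano in place of trifluoromethyl on an aromatic carbon, para to a large group (cyano in place of trifluoromethyl on an aromatic carbon). Among the measured compounds shown here, no measured compound carries cyano, so the data contain no direct precedent for this change. The nearest evidence is indirect: the substituent exchange gives a 1.3-fold higher number from compound 1 to compound 2 (0.11 log units; within the scatter), and the shift of the trifluoromethyl group gives a 1.3-fold higher number from compound 2 to compound 3 (0.11 log units; within the scatter). Neither step leaves the scatter, so no clear change is expected in this assay, and no direction can be favoured with confidence. The expected step is a 1.1-fold lower number from compound 3 to compound 4 (0.05 log units; within the scatter).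

For compound 4 the estimated value is 450 nM, with an expected range of 220 nM to 900 nM.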

Compound 4, half-maximal inhibitory concentration: 340 nM
Beside the measured number, compound 4's estimate is 1.3-fold (0.12 log units) above it; the measured number falls inside the stated range.
By their numbers in this assay, from the lowest: compounds 1, 4, 2 and 3 (each within the scatter of the next).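

In this assay, cyano in place of trifluoromethyl, on an aromatic carbon para to a large group, gives a 1.5-fold lower number from compound 3 to compound 4 (0.17 log units; within the scatter) and is the only reading for a nitrile among the compounds shown. The 4-cyanophenyl compound also stays level with the two other aryl variants, at a 1.1-fold lower number from compound 2 to compound 4 (0.06 log units; within the scatter) and a 1.1-fold higher number from compound 1 to compound 4 (0.05 log units; within the scatter) in this read-out, so trading the four heavy atoms of trifluoromethyl for the two of cyano, with its one hydrogen-bond acceptor, leaves all four compounds within the scatter. No measurement at hand accounts for this flat result.

An amine or a carboxylic acid on this same aromatic carbon might still move the number beyond the scatter. A longer chain linking the amide to the shared core also remains untested among the compounds shown here.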